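Ring size on the thiocarbonyl carbon across two cores

The source may hold more compounds than are shown below. What is called first, only, known or untested is meant among the compounds shown, and "the series" means these compounds.

Compound 1 `O=c1cc(CSC(=S)N2CCCC2)oc2ccccc12` gives 9100 nM in a functional assay on HEp-2 cells (Homo sapiens) for antiproliferative activity, read by MTT assay, with a stated time of 72 h; a higher number here means a weaker inhibitor, a lower number a stronger inhibitor. Compound 2 `O=c1cc(CSC(=S)N2CCCCC2)oc2ccccc12` differs from it by piperidin-1-yl in place of pyrrolidin-1-yl on a thiocarbonyl carbon; in this assay compound 2 gives 12000 nM, which is a step of a 1.3-fold higher number from compound 1 to compound 2 (0.12 log units; within the scatter). Compound 3 `COc1ccc2occ(CSC(=S)N3CCCC3)c(=O)c2c1` rests on a different core; the difference between the two cores is not broken down here. In this assay compound 3 gives 3100 nM, the lowest of the three numbers, beyond the scatter from both compound 1 and compound 2. Compound 4 `COc1ccc2occ(CSC(=S)N3CCCCC3)c(=O)c2c1` has not been measured; it carries the same change as the first pair, (piperidin-1-yl in place of pyrrolidin-1-yl on a thiocarbonyl carbon), on the core of compound 3, and in both pairs the change sits on a thiocarbonyl carbon whose other neighbours are sulfur. The change appears in these two pairs only. Among the measured compounds shown here, its one measured instance, a 1.3-fold higher number from compound 1 to compound 2 (0.12 log units; within the scatter), lies within the scatter, so the expected step from compound 3 to compound 4 in this assay is a 1.3-fold higher number from compound 3 to compound 4 (0.11 log units; within the scatter), resting on that single pair. Compound 4 is accordingly estimated at 4000 nM, with an expected range from 2000 nM to 8000 nM.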

Compound 4, half-maximal inhibitory concentration: 4300 nM
Estimate against measurement, compound 4: 1.1-fold (0.03 log units) below; measured number inside the range.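

In this assay piperidin-1-yl in place of pyrrolidin-1-yl on a thiocarbonyl carbon gives a 1.4-fold higher number from compound 3 to compound 4 (0.14 log units; within the scatter), and this step agrees with the earlier one: the same change on two cores in this assay, a 1.3-fold higher number (0.12 log units; within the scatter) from compound 1 to compound 2 and a 1.4-fold higher number (0.14 log units; within the scatter) from compound 3 to compound 4, 1.1-fold (0.02 log units) apart, within the scatter of two such steps. The change thus carries from one core to the other with no visible difference in size, and on neither core does it move the number beyond the scatter. Two pairs on two cores in a single assay show no more than that: they do not establish that the step would stay this small on a further core, and two steps this small say little about how a larger step would carry over.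

Open, from the compounds shown here alone, is whether another amine on the thiocarbonyl carbon, such as morpholin-4-yl or an open-chain dimethylamino group, would give a step beyond the scatter on either core. Also open is how much of the gap between the two cores belongs to the methoxy group alone, as no pair shown isolates it.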